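A few compounds are considered here, and "the series" means these few. Any claim that something is new, unique, unknown or untested is made for them only; others in the source may bear on it.

Measured so far, all in a functional assay on HeLa cells (Homo sapiens) for antiproliferative activity, with a stated time of 24 h; a lower number here means a stronger inhibitor, a higher number a weaker inhibitor:

compound 1, `NC(=O)c1c(NC(=O)c2ccccc2F)sc2c1CCN(C(=S)Nc1ccccc1Cl)C2`, gives 19400 nM
compound 2, `COc1ccccc1C(=O)Nc1sc2c(c1C(N)=O)CCN(C(=S)Nc1ccccc1Cl)C2`; its result is a limit of the assay, > 50000 nM
compound 3, `CSc1ccccc1C(=O)Nc1sc2c(c1C(N)=O)CCN(C(=S)Nc1ccccc1Cl)C2`, gives 34700 nM

The three share one core and differ only in the group on the benzamide ring. Compound 3 stands highest of the two numbers; its nearest neighbour is compound 1, and the gap a 1.8-fold higher number from compound 1 to compound 3 (0.25 log units; within the scatter) is within the scatter, so no order between them is claimed. The step of an at least 2.5-fold higher number from compound 1 to compound 2 (0.41 log units; beyond the scatter) is the only one beyond the scatter, and it ends at the limit (the limit of > 50000 nM in this assay, at which 1 of the 3 values shown sits). The step of an at least 1.4-fold lower number from compound 2 to compound 3 (0.15 log units; that floor lies within the scatter) has a floor within the scatter.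

Compound 4, `NC(=O)c1c(NC(=O)c2cccc([N+](=O)[O-])c2)sc2c1CCN(C(=S)Nc1ccccc1Cl)C2`, is not yet measured. Relative to compound 3 the change is 3-nitrophenyl in place of 2-(methylsulfanyl)phenyl on a carbonyl carbon. Within the data shown here, none of the measured steps repeats this exchange; they only show that swapping the group on the benzamide ring moves this assay by modest amounts or not at all, and in one case out to the limit. A step in the same modest range is therefore expected for a 1.1-fold lower number from compound 3 to compound 4 (0.04 log units; within the scatter), with no direction held firmly. For compound 4 the estimated value is 32000 nM, with a range from 12000 nM to 85000 nM.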

Compound 4, half-maximal inhibitory concentration: 40300 nM
Compound 4: middle estimate off by 1.3-fold (0.10 log units), on the low side; the range from low to high includes it.
By their numbers in this assay, from the lowest: compounds 1, 3 and 4 (each within the scatter of the next, the first and the last beyond it). At a limit, above all of these: compound 2.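

Notes on the group on the carbonyl carbon: in this assay, compound 4 is the only member shown with a 3-nitrophenyl group, the others carrying 2-fluorophenyl, 2-methoxyphenyl or 2-(methylsulfanyl)phenyl, yet a 1.2-fold higher number from compound 3 to compound 4 (0.06 log units; within the scatter) shows no readable shift for this exchange. Among these compounds, the step of a 2.1-fold higher number from compound 1 to compound 4 (0.32 log units; beyond the scatter) is the first beyond the scatter with a measured number at both ends, so 2-fluorophenyl in compound 1 now holds a modest separation from a group other than the one at the limit, while compound 3 remains unseparated from either compound 1 or compound 4. With compound 2 a limit of the assay and not a number, an at least 1.2-fold lower number from compound 2 to compound 4 (0.09 log units; that floor lies within the scatter) sets no order between the two: the limit of > 50000 nM in this assay, at which 1 of the 4 values shown sits.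

No pair shown keeps one group and changes only its ring position, so 3-fluorophenyl or 2-nitrophenyl would be needed to separate the identity of the group from its place. As far as these compounds go, whether an amine or a carboxylic acid on this ring gives a number lower than that of compound 1 also stays open.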